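Compound 1 to compound 3: hydroxy to methoxy

This account rests on a few compounds, and the source may have more. Where it says the series, first, only, none or still open, it means among the compounds named here.

Compound 1 `O=C(Nc1cccc(-n2cc(-c3ccncc3)c(-c3cc(O)cc(Cl)c3)n2)c1)Nc1ccc(Cl)c(C(F)(F)F)c1` is one of two measured members of this series. In a functional assay on HCT-116 cells (Homo sapiens) for inhibition, read by sulforhodamine B assay, with a stated time of 48 h, tested at 0.1 uM (on this read-out higher numbers stand for a weaker effect at the one concentration tested and lower numbers for a stronger effect), compound 1 gives 103%, the highest of the two numbers, which at this concentration means no measurable effect. Its nearest neighbour is compound 2 `O=C(Nc1cccc(-n2cc(-c3ccncc3)c(-c3cc(O)cc(Cl)c3)n2)c1)Nc1ccc(Cl)c(Cl)c1`, which differs by chloro in place of trifluoromethyl on an aromatic carbon; in this assay compound 2 gives 102%, and the step is a number 1 percentage points lower from compound 1 to compound 2 (within the scatter).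

Compound 3 `COc1cc(Cl)cc(-c2nn(-c3cccc(NC(=O)Nc4ccc(Cl)c(C(F)(F)F)c4)c3)cc2-c2ccncc2)c1` is not yet measured. It differs from compound 1 as follows: methyl in place of hydrogen on an oxygen on an aromatic ring. Among the measured compounds shown here, none of the measured steps touches the oxygen on the aromatic ring, so the only step available, a number 1 percentage points lower from compound 1 to compound 2 (within the scatter), does not bear on this change. For the measured compounds named here, the two measured numbers sit together at the level where nothing is inhibited, and the single small change in compound 3 gives no ground for expecting a step beyond the scatter in this assay.

Compound 3 is therefore expected to give 100% in this assay, with a range from 86% to 112%, an expected step of a number 3 percentage points lower from compound 1 to compound 3 (within the scatter).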

Compound 3, a percentage reported as activity, at one concentration (the size of the read-out at that concentration, not a potency): 97%
Compound 3: middle estimate off by 3 percentage points, on the high side, within the range that was stated.
By their numbers in this assay, from the lowest: compounds 3, 2 and 1 (each within the scatter of the next).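

In this assay, the change at the oxygen on the aromatic ring gives a number 6 percentage points lower from compound 1 to compound 3 (within the scatter), so this position now has a measured step of its own, and methyl in place of hydrogen there produces no shift beyond the scatter. The free hydroxy is therefore not needed for the read-out to stay where it stands, but that level is one of little or no effect, and the result cannot separate the hydroxy and methoxy forms or show that either has any activity at the one concentration tested. No measured property of either group bears on this result.

Still open, going by these compounds, is whether a longer chain on this oxygen, such as a benzyl group, or an amine or a carboxylic acid in place of the hydroxy, would bring the read-out beyond the scatter. Also open, on these data alone, is whether 3-chloro-5-hydroxyphenyl and 3-chloro-5-methoxyphenyl would differ at a concentration where the series shows clear inhibition.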